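A few compounds are considered here, and "the series" means these few. Any claim that something is new, unique, unknown or untested is made for them only; others in the source may bear on it.

Measured so far:
- compound 1, `CC[C@@H](C)[C@H](NC(=O)c1ccc(C(CC)(CC)c2ccc(OCC(=O)C(C)(C)C)c(C)c2)n1CC)C(=O)OC`: 590 nM
- compound 2, `CCN(CC)CCNC(=O)c1ccc(C(CC)(CC)c2ccc(OCC(=O)C(C)(C)C)c(C)c2)n1CC`: 91 nM
- compound 3, `C#CCCOC(=O)c1ccc(C(CC)(CC)c2ccc(OCC(=O)C(C)(C)C)c(C)c2)n1CC`: 28800 nM

All three share the same core and differ only in the group attached to one carbonyl carbon. In an assay on HL-60 cells for agonist activity at vitamin D3 receptor (Homo sapiens), read by microscopy, with a stated time of 96 h (on this read-out lower numbers stand for an effect already at smaller amounts and higher numbers for an effect only at larger amounts of compound), compound 3 gives the highest number of the three. Its nearest neighbour is compound 1, and the step is a 49-fold higher number from compound 1 to compound 3 (1.69 log units; beyond the scatter); its furthest is compound 2, with a 320-fold higher number from compound 2 to compound 3 (2.50 log units; beyond the scatter). Both steps exchange an amide-type nitrogen group for an ether oxygen on that carbonyl carbon, and both move the number sharply upward.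

Compound 4, `CCn1c(C(=O)Nc2ccc(OC(F)(F)F)cc2)ccc1C(CC)(CC)c1ccc(OCC(=O)C(C)(C)C)c(C)c1`, returns to an amide: (4-(trifluoromethoxy)phenyl)amino in place of (but-3-yn-1-yl)oxy on a carbonyl carbon. The two amide compounds already measured both sit far below compound 3, so the same kind of swap is expected to lower the number by a large amount here as well. The two amides differ from each other by a 6.5-fold lower number from compound 1 to compound 2 (0.81 log units; beyond the scatter), which shows that the exact group on the amide nitrogen matters, and no aromatic amide has yet been measured, so the landing point is uncertain.

Compound 4 is therefore expected to give about 300 nM in this assay, within a range of 50 nM to 2000 nM, a step of a 96-fold lower number from compound 3 to compound 4 (1.98 log units; beyond the scatter).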

Compound 4, half-maximal effective concentration: > 50000 nM
Compound 4 ended at the assay's limit; the forecaster's own chance of this, stated with the estimate: 5%; at least 160-fold (2.22 log units) between middle value and limit.
By their numbers in this assay, from the lowest: compound 2; then compound 1; then compound 3. At a limit, above all of these: compound 4.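

In this assay, compound 4 gives no number but a limit of the assay: the limit of > 50000 nM in this assay, at which 1 of the 4 values shown sits.

An amide on this carbonyl carbon therefore does not by itself keep the number low. Placing 4-(trifluoromethoxy)phenyl on the amide-type nitrogen gives an at least 540-fold higher number from compound 2 to compound 4 (2.73 log units; beyond the scatter) and an at least 84-fold higher number from compound 1 to compound 4 (1.92 log units; beyond the scatter), so among the three amides the group on that nitrogen makes a large difference, and compound 4 goes against the earlier impression that amides sit far below the compound with (but-3-yn-1-yl)oxy. Exchanging that group for (4-(trifluoromethoxy)phenyl)amino gives an at least 1.7-fold higher number from compound 3 to compound 4 (0.23 log units; that floor lies within the scatter), so this step does not establish an order between the two groups.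

The compounds shown do not tell whether the result of compound 4 goes with the phenyl ring itself or with its trifluoromethoxy group, a question that an unsubstituted phenyl on the amide nitrogen would address. They also leave open whether the diethylamino group of compound 2 is needed for its low number, which a plain butyl chain or a 2-hydroxyethyl group in place of 2-(diethylamino)ethyl would test.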